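The source may hold more compounds than are shown below. What is called first, only, known or untested is meant among the compounds shown, and "the series" means these compounds.

Compound 3 `CCNC(=O)c1cc(C(=O)NC)nn1[C@@H](C)c1ccccc1` stands high among the three measured compounds. In a physicochemical assay for solubility (a higher number here means a more soluble compound, a lower number a less soluble compound), compound 3 gives >= 137 ug/mL, which is a limit of the assay rather than a number. Compound 1 `CNC(=O)c1cc(C(=O)NC2CCOCC2)n([C@@H](C)c2ccccc2)n1` gives 31 ug/mL in this assay. Compound 2 `CNC(=O)c1cc(C(=O)N[C@H]2[C@@H]3C[C@@H](O)C[C@@H]32)n([C@@H](C)c2ccccc2)n1` gives >= 291 ug/mL, also a limit of the assay. Compound 4 `CNC(=O)c1cc(C(=O)NC2CC2)n([C@@H](C)c2ccccc2)n1` differs from compound 3 by cyclopropyl in place of ethyl on an amide-type nitrogen. Two measured steps change the same amide nitrogen: an at least 4.4-fold higher number from compound 1 to compound 3 (0.64 log units; beyond the scatter) and an at least 9.3-fold higher number from compound 1 to compound 2 (0.97 log units; beyond the scatter), while a step that the two limits leave unreadable from compound 2 to compound 3. Neither step sets ethyl against cyclopropyl, so no direction can be read from them, and a step no larger than the scatter is expected, namely an at least 1.1-fold lower number from compound 3 to compound 4 (0.05 log units; that floor lies within the scatter). Compound 4 is therefore estimated to give 120 ug/mL, somewhere between 50 ug/mL and 300 ug/mL.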

Compound 4, solubility: >= 165 ug/mL
Compound 4 gave a limit, no number; the forecaster's own chance of this, stated with the estimate: 40%; at least 1.3-fold (0.13 log units) between middle value and limit.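

In this assay, cyclopropyl on the amide-type nitrogen in place of oxan-4-yl gives an at least 5.3-fold higher number from compound 1 to compound 4 (0.72 log units; beyond the scatter). Compound 1, with oxan-4-yl, thus stays lowest of the four, whether ethyl, cyclopropyl or the two-ring group of compound 2 takes that place. Compound 4 gives a limit, not a number: the limit of >= 165 ug/mL in this assay, at which 1 of the 4 values shown sits.

The steps among compound 2, compound 3 and compound 4 cannot be read, so ethyl and cyclopropyl remain unranked. Going by these compounds, how a longer chain such as butyl, or a group carrying an amine, would read on this nitrogen also stays open.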